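A few compounds are considered here, and "the series" means these few. Any claim that something is new, unique, unknown or untested is made for them only; others in the source may bear on it.

In a functional assay on MGC-803 cells (Homo sapiens) for cytotoxicity, read by MTT assay, with a stated time of 72 h (on this read-out higher numbers stand for weaker inhibition and lower numbers for stronger inhibition), three compounds built on one shared core have been measured. Compound 1 `COc1ccc(C=C2C(=O)N(c3ccc(Cl)cc3)N(c3ccc(Cl)cc3)C2=O)cc1` reaches only the limit of the measurement, > 128000 nM, in this assay. Compound 2 `COc1ccc(C=C2C(=O)N(c3ccc(Cl)cc3)N(c3ccc(Cl)cc3)C2=O)cc1OC` likewise gives only a limit, > 128000 nM, in this assay. Among the compounds with values here, compound 3 `COc1cccc(C=C2C(=O)N(c3ccc(Cl)cc3)N(c3ccc(Cl)cc3)C2=O)c1OC` is the sole compound with a number, 29600 nM in this assay. The change hydrogen in place of methoxy on an aromatic carbon gives a step that the two limits leave unreadable from compound 2 to compound 1, because both values sit at the limit of > 128000 nM in this assay, at which 2 of the 3 values shown sit. The change 2,3-dimethoxyphenyl in place of 3,4-dimethoxyphenyl on a double-bonded chain carbon bound to a double-bonded ring carbon gives an at least 4.3-fold lower number from compound 2 to compound 3 (0.63 log units; beyond the scatter), and an at least 4.3-fold lower number from compound 1 to compound 3 (0.63 log units; beyond the scatter) is of the same size.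

Compound 4 `COc1ccccc1C=C1C(=O)N(c2ccc(Cl)cc2)N(c2ccc(Cl)cc2)C1=O` is not yet measured. It differs from compound 3 by hydrogen in place of methoxy on an aromatic carbon, the same change as that from compound 2 to compound 1, whose size is not readable. From compound 3 to compound 4 a step of about a 1.7-fold higher number from compound 3 to compound 4 (0.23 log units; within the scatter) is expected in this assay, resting on compound 3 at 29600 nM and on the unreadable a step that the two limits leave unreadable from compound 2 to compound 1, which leaves the direction open. Compound 4 is estimated at 50000 nM, between 15000 nM and 128000 nM.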

Compound 4, half-maximal inhibitory concentration: 28600 nM
Estimate against measurement, compound 4: 1.7-fold (0.24 log units) above; the range from low to high includes it.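

In this assay, hydrogen in place of methoxy on the core of compound 3 gives a 1.0-fold lower number from compound 3 to compound 4 (0.01 log units; within the scatter), so on this core the change leaves the read-out within the scatter. Compound 4 also stands apart from the compounds that reach only the limit, with an at least 4.4-fold lower number from compound 2 to compound 4 (0.65 log units; beyond the scatter) and an at least 4.4-fold lower number from compound 1 to compound 4 (0.65 log units; beyond the scatter), so the 2-methoxyphenyl compound keeps the separation that the 2,3-dimethoxyphenyl compound shows. This does not show that the change carries over from one core to the other, because the same change on the 3,4-dimethoxyphenyl compound cannot be read, both of its values being limits: the limit of > 128000 nM in this assay, at which 2 of the 4 values shown sit.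

The compounds shown leave open what an amine or a carboxylic acid in place of the methoxy group of compound 4 would give in this assay. They also leave open what a plain phenyl group would give there, and whether replacing the chlorine atoms on the shared core with fluorine would alter these steps.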